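Fluoro for Methyl in a Weakly Cytotoxic Series

The compounds below may be only part of what the source reports. "The series", "measured", "known", "first", "only" and "open" are said of these compounds alone.

Compound 1 `Cc1ccc(-c2nnc(COc3ccc(C#N)c(F)c3)o2)cc1` was tested in a functional assay on MDA-MB-453 cells (Homo sapiens) for cytotoxicity, read by MTT assay, with a stated time of 48 h; a higher number here means a weaker inhibitor, a lower number a stronger inhibitor. In this assay compound 1 reaches only the limit of > 50000 nM, which is a boundary of the measurement and not a number. Compound 2 `N#Cc1ccc(OCc2nnc(-c3ccc(F)cc3)o2)cc1F` differs from compound 1 by fluoro in place of methyl on an aromatic carbon and in this assay compound 2 gives 25100 nM. That change made a step of an at least 1.9-fold lower number from compound 1 to compound 2 (0.29 log units; that floor lies within the scatter), and its size is known only as a floor because of the limit of > 50000 nM in this assay, at which 2 of the 3 values shown sit.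

Compound 3 `Cc1ccc(-c2nnc(COc3ccc(-c4nnco4)cc3)o2)cc1` carries a different end group on the shared core; how compound 1 and compound 3 differ is not broken down here. In this assay compound 3 also reaches only the limit of > 50000 nM, again a boundary rather than a number.

Compound 4 `Fc1ccc(-c2nnc(COc3ccc(-c4nnco4)cc3)o2)cc1` has not yet been measured. It differs from compound 3 by fluoro in place of methyl on an aromatic carbon, the same change that separates compound 1 from compound 2, at the same kind of position on the ring. Among the measured compounds shown here, the only guide is the step from compound 1 to compound 2, which rests on one limit and one number, so its true size is uncertain. On that basis the step from compound 3 to compound 4 is expected to be about an at least 1.6-fold lower number from compound 3 to compound 4 (0.22 log units; that floor lies within the scatter). Compound 4 is therefore estimated to give roughly 30000 nM in this assay, plausibly anywhere from 10000 nM to 100000 nM, with a real chance that only a limit is reported.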

Compound 4, half-maximal inhibitory concentration: 38200 nM
Beside the measured number, compound 4's estimate is 1.3-fold (0.10 log units) below it; low and high end bracket the measured number.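

In this assay, the change from 4-methylphenyl to 4-fluorophenyl on the second core gives an at least 1.3-fold lower number from compound 3 to compound 4 (0.11 log units; that floor lies within the scatter). This shows that on both cores the methyl compound reaches only a limit while the fluoro compound gives a real number, so the change can be carried from one core to the other without the result turning the opposite way, but it does not show that the step has the same size on both cores or that either step stands clear of the usual scatter: the same change on two cores in this assay, an at least 1.9-fold lower number (0.29 log units; that floor lies within the scatter) from compound 1 to compound 2 and an at least 1.3-fold lower number (0.11 log units; that floor lies within the scatter) from compound 3 to compound 4; the limit leaves it open whether they differ. The true size of each step remains unknown, and each is known only as a floor, because the methyl compound on each core sits at a boundary of the measurement: the limit of > 50000 nM in this assay, at which 2 of the 4 values shown sit.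

The compounds shown leave open whether another group at this place on the ring, such as chloro, methoxy or an amine, would give a number well clear of the limit in this assay. They also leave open whether the change from 4-methylphenyl to 4-fluorophenyl would behave in the same way on any core other than these two.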